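Ring swap on the amide nitrogen: volume of distribution

The compounds below may be only part of what the source reports. "The series", "measured", "known", "first", "only" and "open" are said of these compounds alone.

In an ADME assay on the whole organism (Canis lupus familiaris, strain Beagle) for pharmacokinetics, read by LC-MS, with a stated time of 7 h (a higher number here means that more of the compound sits outside the plasma, a lower number that more of the compound stays in the plasma), compound 1 `CNC(=O)c1cc(C(=O)N[C@H]2[C@@H]3COC[C@@H]32)c([C@@H](C)c2ccccc2)o1` gives 1.1 L/kg and compound 2 `CNC(=O)c1cc(C(=O)N[C@H]2[C@@H]3C[C@@H](O)C[C@@H]32)c([C@@H](C)c2ccccc2)o1` gives 1.1 L/kg, so compound 2 stands level with compound 1 at the digits available. The next structure is compound 3 `CNC(=O)c1cc(C(=O)N[C@H]2CC[C@H](O)CC2)c([C@@H](C)c2ccccc2)o1`, which keeps the shared core and changes one group: a group of 7 heavy atoms (6 carbon, 1 oxygen; one six-membered non-aromatic ring of carbon only) in place of a group of 7 heavy atoms (6 carbon, 1 oxygen; one three-membered non-aromatic ring of carbon only, one five-membered non-aromatic ring of carbon only), on an amide-type nitrogen. A 4-hydroxycyclohexyl group thus takes over the place on the amide-type nitrogen. For the measured compounds named here, only one measured step bears on this: no change at the digits printed from compound 1 to compound 2 (within the scatter), a replacement at the same place. Going by the values given here, that is a single step, and no measured compound yet carries a six-membered ring of carbon there, so the support is thin. On that basis, no shift beyond the scatter is expected in this assay. The expected step is no change at the digits printed from compound 2 to compound 3 (within the scatter). Compound 3 is estimated at 1.1 L/kg, with an expected range of 0.6 L/kg to 2 L/kg.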

Compound 3, volume of distribution at steady state: 0.8 L/kg
Estimate against measurement, compound 3: 1.4-fold (0.14 log units) above, and the stated range covers the measured number.
By their numbers in this assay, from the lowest: compounds 3, 1 and 2 (each within the scatter of the next).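

Replacing the two-ring groups on the amide-type nitrogen with a single six-membered ring of carbon, the 4-hydroxycyclohexyl group, leaves this assay within the scatter, with a 1.4-fold lower number from compound 2 to compound 3 (0.14 log units; within the scatter) and a 1.4-fold lower number from compound 1 to compound 3 (0.14 log units; within the scatter) as the two steps. Across the three groups shown at this place, each with one oxygen, no step goes beyond the scatter, and that now includes a group with no three-membered ring. Nothing available here speaks to why the numbers stay together.

From the compounds shown here alone, whether a group without oxygen at this place, such as plain cyclohexyl, or one carrying an amine or a carboxylic acid, would move the number beyond the scatter remains open. Also open, going by these compounds, is whether the other stereoisomer of 4-hydroxycyclohexyl would stay level with compound 3.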